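This account rests on a few compounds, and the source may have more. Where it says the series, first, only, none or still open, it means among the compounds named here.

In an ADME assay on A549 cells (Homo sapiens) for cytotoxicity, read by MTT assay (on this read-out higher numbers stand for lower toxicity in this test and lower numbers for higher toxicity in this test), compound 1 (`CCCCCCCCCCNc1ccn([C@H]2C[C@H](O)[C@@H](CO)O2)c(=O)n1`) gives 200000 nM, compound 2 (`CCCCCCNc1nc(=O)n([C@H]2C[C@H](O)[C@@H](CO)O2)cc1C`) gives 90000 nM and compound 3 (`CCCCCCCCNc1nc(=O)n([C@H]2C[C@H](O)[C@@H](CO)O2)cc1C`) gives 90000 nM. Compound 3 is thus level with compound 2, the two sharing the lowest of the three numbers, while compound 1 stands above them by more than the scatter. Compound 4 (`CCCCCCCCCCNc1nc(=O)n([C@H]2C[C@H](O)[C@@H](CO)O2)cc1C`) departs from compound 3 by one change: ethyl in place of hydrogen on a saturated chain carbon, eight bonds along the chain from a nitrogen on an aromatic ring. This is ethyl in place of hydrogen on a saturated chain carbon, eight bonds along the chain from a nitrogen on an aromatic ring. Going by the values given here, only one measured step bears on it: no change at the digits printed from compound 2 to compound 3 (within the scatter). That step made the same exchange, six bonds along the chain from a nitrogen on an aromatic ring. No single measured change joins compound 1 to the others, so it only widens the upper side of the range. With that one step as the guide, no shift beyond the scatter is expected in this assay. The expected step is a 1.1-fold higher number from compound 3 to compound 4 (0.05 log units; within the scatter). Compound 4 is estimated at 100000 nM, with an expected range from 50000 nM to 200000 nM.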

Compound 4, half-maximal cytotoxic concentration: 156000 nM
Compound 4: middle estimate off by 1.6-fold (0.19 log units), on the low side; the range from low to high includes it.
By their numbers in this assay, from the lowest: compounds 2, 3, 4 and 1 (each within the scatter of the next, the first and the last beyond it).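

In this assay, the ethyl exchange eight bonds along the chain stays within the scatter (a 1.7-fold higher number from compound 3 to compound 4 (0.24 log units; within the scatter)), and so does the butyl exchange six bonds along the chain (a 1.7-fold higher number from compound 2 to compound 4 (0.24 log units; within the scatter)), so no step beyond the scatter appears among the three compounds that differ only in chain length at this place. Compound 4 also gives compound 1 its first single-change link to the series: methyl in place of hydrogen on an aromatic carbon also stays within the scatter (a 1.3-fold lower number from compound 1 to compound 4 (0.11 log units; within the scatter)). No measurement available here accounts for these numbers.

Going by these compounds, whether a longer chain, or a chain carrying a hydroxyl or an amine, would leave the number within this range remains open. Also open, on these data alone, is what chlorine, in place of methyl, would give on that aromatic carbon.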